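The compounds below may be only part of what the source reports. "The series", "measured", "known", "first", "only" and "open" are said of these compounds alone.

Going by the values given here, compound 2 `CCOC(C)COC1CCN(c2nc(N)c3cc(OC)c(OC)cc3n2)CC1` holds the lowest of the two numbers so far in an assay on brain for displacement of a labelled ligand from Adrenergic receptor alpha-1 (Rattus norvegicus) (on this read-out higher numbers stand for weaker inhibition and lower numbers for stronger inhibition), with compound 2 giving 0.99 nM. Among the compounds with values here, its neighbour, compound 1 `COc1cc2nc(N3CCC(OCCO)CC3)nc(N)c2cc1OC`, is the only other measured member; in this assay compound 1 gives 2.2 nM. Within the data shown here, the single measured step, a 2.2-fold lower number from compound 1 to compound 2 (0.35 log units; beyond the scatter), arose when the hydroxymethyl on the ether side chain was replaced by 1-ethoxyethyl, a modest gain.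

Compound 3 `CCOC(C)(COC1CCN(c2nc(N)c3cc(OC)c(OC)cc3n2)CC1)c1ccccc1` carries the next change on that same chain: phenyl in place of hydrogen on a saturated chain carbon bound to an oxygen on a saturated carbon and two saturated chain carbons. Among the measured compounds shown here, only the step from compound 1 to compound 2 bears on it, and it was modest; it shows that enlarging this side chain did not cost binding, but says nothing about a phenyl at that carbon. The expected step in this assay is therefore a 1.1-fold lower number from compound 2 to compound 3 (0.04 log units; within the scatter), small and within or near the scatter. Compound 3 is estimated at 0.9 nM, with a range from 0.3 nM to 3 nM.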

Compound 3, inhibition constant: 0.15 nM
Compound 3: the middle estimate sits 6.0-fold (0.78 log units) above what was measured, and the stated range ends above it.
By their numbers in this assay, from the lowest: compound 3; then compound 2; then compound 1.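

In this assay, going by these compounds alone, phenyl in place of hydrogen on the saturated chain carbon gave a 6.6-fold lower number from compound 2 to compound 3 (0.82 log units; beyond the scatter), which shows that this carbon accepts a phenyl and that the number falls further with it, something the earlier compounds, both without a ring on the side chain, could not show. Taken whole, the change from hydroxymethyl to 1-ethoxy-1-phenylethyl gave a 15-fold lower number from compound 1 to compound 3 (1.17 log units; beyond the scatter), the only step so far graded large. Nothing available explains why the phenyl lowers the number.

The compounds shown leave open whether a methyl at this carbon would lower the number too, or whether a ring is needed, and whether a 4-fluorophenyl or a pyridyl would serve as well as phenyl. They also leave open whether the ethoxy still contributes once the phenyl is present, or whether a hydroxyl could take its place.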